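This account rests on a few compounds, and the source may have more. Where it says the series, first, only, none or still open, it means among the compounds named here.

In a functional assay on PANC-1 cells (Homo sapiens) for cytotoxicity, read by WST assay, with a stated time of 24 h (on this read-out higher numbers stand for weaker inhibition and lower numbers for stronger inhibition), three compounds have been read so far. Compound 1 `O=C(CCCCCCCCc1ccccc1)N1CCCCC1` gives > 100000 nM, which is a limit of the assay and not a number. Among the measured compounds shown here, compound 2 `O=C(CCCCCCCCc1ccccc1F)N1CCCCC1` gives 98900 nM, the only true number in the set. Compound 3 `O=C(CCCCCCCCc1cccc(F)c1)N1CCCCC1` gives > 100000 nM, and this too is only a limit. The set therefore crowds at the limit of > 100000 nM in this assay, at which 2 of the 3 values shown sit, and compound 3 stands there with no exact value.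

Compound 4 `O=C(CCCCCCCCc1ccc(Cl)cc1)N1CCCCC1` comes next, and its change from compound 3 is 4-chlorophenyl in place of 3-fluorophenyl on a saturated chain carbon, eight bonds along the chain from a carbonyl carbon. The measured steps that bear on it all concern fluoro on the aromatic ring. Adding fluoro gives a number no higher from compound 1 to compound 2 (the limit leaves the size open) and also a step that the two limits leave unreadable from compound 1 to compound 3, while exchanging the two fluorophenyl groups gives a number no lower from compound 2 to compound 3 (the limit leaves the size open). For the measured compounds named here, none of these has a readable size, and no measured compound carries chlorine.

The expectation rests on compound 2 at 98900 nM, so no large change is foreseen in this assay and no direction can be argued. The expected move is an at least 1.1-fold lower number from compound 3 to compound 4 (0.04 log units; that floor lies within the scatter). For compound 4 the estimate is 90000 nM, with an expected range from 40000 nM to 200000 nM. A further limit would be no surprise.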

Compound 4, half-maximal inhibitory concentration: 65500 nM
Beside the measured number, compound 4's estimate is 1.4-fold (0.14 log units) above it; the measured number falls inside the stated range.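

Compound 4 is the only compound shown that carries chlorine, and in this assay its 4-chlorophenyl group gives the set a second true number at this place on the saturated chain, eight bonds along the chain from a carbonyl carbon. Against the one other true number the change reads as a 1.5-fold lower number from compound 2 to compound 4 (0.18 log units; within the scatter), so the two compounds cannot be told apart, and the swap of one halogen-bearing phenyl group for the other shows no effect that stands clear of the usual variation. The two remaining steps, an at least 1.5-fold lower number from compound 3 to compound 4 (0.18 log units; that floor lies within the scatter) and an at least 1.5-fold lower number from compound 1 to compound 4 (0.18 log units; that floor lies within the scatter), give only floors that lie within the scatter, because each starts from a compound with no exact value: the limit of > 100000 nM in this assay, at which 2 of the 4 values shown sit.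

Among the compounds shown here, no step that can be read in this set yet stands beyond the scatter, so it remains open whether any change on this phenyl ring can move the number clearly. A ring bearing an amine or a carboxylic acid in place of the halogen, or a longer chain between the ring and the carbonyl, might show more than fluoro and chloro do here.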